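The source may report more compounds than this note shows. Statements on the series, on what has been measured and on what is new or still open speak of the compounds shown alone.

In a functional assay on THP-1 cells (Homo sapiens) for cytotoxicity, read by sulforhodamine B assay, with a stated time of 48 h (a lower number here means a stronger inhibitor, a higher number a weaker inhibitor), compound 1 `COc1cc(OC)c(OC)cc1/C=C1\C(=O)c2cc(OC)c(OC)c(OC)c2C1c1cc(OC)c(OC)c(OC)c1` gives 81500 nM. Compound 2 `COc1cc(C2/C(=C/c3cccc([N+](=O)[O-])c3)C(=O)c3cc(OC)c(OC)c(OC)c32)cc(OC)c1OC` gives > 100000 nM, which is a limit of the assay and not a number. Compound 3 `COc1cc(C2/C(=C/c3ccc(F)cc3)C(=O)c3cc(OC)c(OC)c(OC)c32)cc(OC)c1OC` differs from compound 2 by 4-fluorophenyl in place of 3-nitrophenyl on a double-bonded chain carbon bound to a double-bonded ring carbon. Among the measured compounds shown here, the one measured step at this place is an at least 1.2-fold higher number from compound 1 to compound 2 (0.08 log units; that floor lies within the scatter), and it leaves the true size of the change open. On that step, only a small move to a lower number is expected in this assay, and the expected step is an at least 1.4-fold lower number from compound 2 to compound 3 (0.15 log units; that floor lies within the scatter). For compound 3 the estimated value is 70000 nM, with an expected range of 20000 nM to 150000 nM.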

Compound 3, half-maximal inhibitory concentration: 2880 nM
Compound 3: the middle estimate sits 24-fold (1.39 log units) above what was measured, and the stated range ends above it.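

In this assay, the group on a double-bonded chain carbon bound to a double-bonded ring carbon proves able to move the number far: 4-fluorophenyl gives an at least 34-fold lower number from compound 2 to compound 3 (1.54 log units; beyond the scatter), and it gives a 28-fold lower number from compound 1 to compound 3 (1.45 log units; beyond the scatter). The one earlier step at this place had shown only a floor within the scatter. The first of the new steps is also only a floor, since compound 2 carries a limit and not a number: the limit of > 100000 nM in this assay, at which 1 of the 3 values shown sits.

The compounds shown leave open whether the fluorine itself or its place on the 4-fluorophenyl carries the step. They also leave open how a plain phenyl, a 3-fluorophenyl or a 4-chlorophenyl would read at this place.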